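Hydrogen for Amino: One Step from a Weak Cytotoxin

The source may hold more compounds than are shown below. What is called first, only, known or untested is meant among the compounds shown, and "the series" means these compounds.

Measured so far:
compound 1, `Nc1ccc2sc(NC(=S)NC(=O)c3ccccc3)nc2c1`: 70100 nM
compound 2, `CCCCC(=O)NC(=S)Nc1nc2cc([N+](=O)[O-])ccc2s1`: "not determined" (no result reported)

Compound 1 was tested in a functional assay on HeLa cells (Homo sapiens) for cytotoxicity, read by MTT assay, with a stated time of 24 h (a higher number here means a weaker inhibitor, a lower number a stronger inhibitor), and gives 70100 nM there, a weak effect. Among the compounds with values here, it is the only number in hand: compound 2 carries "not determined" (no result reported) in this assay, so it gives no point of comparison, and no pair of measured compounds differing in a single place is available to show how large a change in this assay a single substitution brings.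

Compound 3, `O=C(NC(=S)Nc1nc2ccccc2s1)c1ccccc1`, differs from compound 1 in one place: hydrogen in place of amino on an aromatic carbon. The rest of the shared core and the acylthiourea side chain are unchanged.

Within the data shown here, with no measured step to lean on, the author expects the change to stay close to what compound 1 shows, and the estimated step from compound 1 to compound 3 is a 1.2-fold lower number from compound 1 to compound 3 (0.07 log units; within the scatter), not clearly beyond the usual scatter. Compound 3 is therefore expected to give about 60000 nM in this assay, within a range from 20000 nM to 150000 nM.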

Compound 3, half-maximal inhibitory concentration: 57500 nM
Estimate against measurement, compound 3: 1.0-fold (0.02 log units) above, within the range that was stated.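

The first single-place step available in this assay is a 1.2-fold lower number from compound 1 to compound 3 (0.09 log units; within the scatter), and it sits within the usual scatter, so compound 1 and compound 3 cannot be told apart in this assay. Until now, no measured pair had shown what a substitution on this aromatic carbon does; this one shows that hydrogen in place of amino, at the position meta to a fused ring and para to a fused ring, leaves the reading indistinguishable, and that the amino group is not needed for the weak cytotoxicity seen here. Nothing at hand explains why the two compounds read alike, as no supporting measurement bears on the result.

Within the data shown here, since hydrogen and amino are the only two groups with numbers at this position, it remains open whether a carboxylic acid or a methoxy group on the same carbon would move the reading beyond the scatter. On these data alone, it also remains open whether a change in the acylthiourea side chain, such as a longer alkyl chain in place of the phenyl ring, would matter more than this substitution on the aromatic ring.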